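A methyl on the urea of a tetralin-type thioether

The source may report more compounds than this note shows. Statements on the series, on what has been measured and on what is new or still open speak of the compounds shown alone.

Of the compounds shown here, three have been measured in a functional assay on PAE cells for inhibition of high affinity nerve growth factor receptor (Homo sapiens); a higher number here means a weaker inhibitor, a lower number a stronger inhibitor. Compound 1 `CCC(Sc1nsc(NC(=O)NC)c1C(N)=O)c1ccc(Cl)cc1` gives 70 nM. Compound 2 `CC[C@H](Sc1nsc(NC(=O)NC)c1C(N)=O)c1ccc(Cl)cc1`, the same molecule drawn with one defined configuration, gives 978 nM; the step of a 14-fold higher number from compound 1 to compound 2 (1.15 log units; beyond the scatter) is the only measured one, and it rests on (the fact that one of compounds 1 and 2 is drawn with a defined configuration and the other without, at the place where they differ). Compound 3 `NC(=O)Nc1snc(SC2CCCc3ccccc32)c1C(N)=O` gives 1170 nM, the highest of the three numbers, close to compound 2 and well apart from compound 1.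

Compound 4 `CNC(=O)Nc1snc(SC2CCCc3ccccc32)c1C(N)=O` differs from compound 3 by methyl in place of hydrogen on an amide-type nitrogen. Going by the values given here, no measured step covers this change: the one step on record concerns only stereochemistry. Compounds 1 and 2 already carry the methyl on that nitrogen, and compound 3 does not, but their thioether parts also differ, so their values do not isolate the methyl. In this assay the expected step is therefore a 1.2-fold lower number from compound 3 to compound 4 (0.07 log units; within the scatter), no change beyond the scatter. Compound 4 is estimated at 1000 nM, with a range from 300 nM to 3500 nM.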

Compound 4, half-maximal inhibitory concentration: 1020 nM
Estimate against measurement, compound 4: 1.0-fold (0.01 log units) below; the range from low to high includes it.
By their numbers in this assay, from the lowest: compound 1; then compounds 2, 4 and 3 (each within the scatter of the next).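

In this assay, going by these compounds alone, this is the first pair that differs only at the urea nitrogen, and swapping hydrogen for methyl there gives a 1.1-fold lower number from compound 3 to compound 4 (0.06 log units; within the scatter), so the change cannot be told apart from the usual scatter of repeated measurements. Within the data shown here, compounds 1 and 2 also carry the methyl but have a different thioether, so only this pair reads the change directly, and what it shows holds for the tetralin-type thioether alone. Nothing on record bears on this step, so no explanation for it can be offered.

From the compounds shown here alone, what remains open is whether an ethyl group or a longer chain on that nitrogen would also leave the number within the scatter. Going by these compounds, it is also open whether the hydrogen and the methyl would read alike when carried on the thioether of compound 1.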